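Swapping the aryl group on the anilino nitrogen of compound 2

A few compounds are considered here, and "the series" means these few. Any claim that something is new, unique, unknown or untested is made for them only; others in the source may bear on it.

In a functional assay on MGC-803 cells (Homo sapiens) for inhibition, read by MTT assay, with a stated time of 72 h (on this read-out lower numbers stand for stronger inhibition and higher numbers for weaker inhibition), compound 2 `C=CC(=O)Nc1cccc(NC(=O)CSc2nc(Nc3ccc(CC)cc3)c3ccccc3n2)c1` gives 8010 nM, the lowest of the two numbers recorded so far. Its nearest neighbour is compound 1 `C=CC(=O)Nc1cccc(NC(=O)CSc2nc(Nc3ccc(Br)cc3)c3ccccc3n2)c1`, which in this assay gives 11500 nM; the step of a 1.4-fold lower number from compound 1 to compound 2 (0.16 log units; within the scatter) is within the scatter, so the two compounds cannot be ordered on these numbers.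

Compound 3 `C=CC(=O)Nc1cccc(NC(=O)CSc2nc(Nc3ccc(Cl)c(Cl)c3)c3ccccc3n2)c1` has not yet been measured in this assay. It differs from compound 2 by 3,4-dichlorophenyl in place of 4-ethylphenyl on a nitrogen on an aromatic ring. Going by the values given here, the only measured step that touches the same aryl group, a 1.4-fold lower number from compound 1 to compound 2 (0.16 log units; within the scatter), exchanged a halogen for an alkyl group at one position of that ring and produced no change beyond the scatter. Nothing measured here tells how a second chlorine on that ring would act, so the expectation rests on that one small step.

Compound 3 is therefore expected to land close to compound 2, with the step of a 1.1-fold higher number from compound 2 to compound 3 (0.05 log units; within the scatter) lying within the scatter. The estimate for compound 3 in this assay is 9000 nM, with a range from 4000 nM to 20000 nM.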

Compound 3, half-maximal inhibitory concentration: > 50000 nM
Compound 3 was reported as a limit; the forecaster's own chance of this, stated with the estimate: 5%; at least 5.5-fold (0.74 log units) between middle value and limit.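

In this assay, the entry for compound 3 is a limit of the assay and not a number: the limit of > 50000 nM in this assay, at which 1 of the 3 values shown sits. The aryl group on this nitrogen had so far shown no effect beyond the scatter, as the exchange of bromo for ethyl gave a 1.4-fold lower number from compound 1 to compound 2 (0.16 log units; within the scatter), whereas the new group gives an at least 6.2-fold higher number from compound 2 to compound 3 (0.79 log units; beyond the scatter) and an at least 4.3-fold higher number from compound 1 to compound 3 (0.63 log units; beyond the scatter), so the read-out does respond to what this position carries. The 3,4-dichlorophenyl group matches 4-ethylphenyl in its 8 heavy atoms and its six-membered aromatic ring of carbon only, and neither group has hydrogen-bond donors or acceptors, so these counts do not separate two groups that differ beyond the scatter.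

As far as these compounds go, the true size of both new steps stays open, since one end of each is a limit, and so does whether the second chlorine or the particular pattern of substitution on the ring accounts for the loss. A phenyl ring carrying a single chlorine, a methoxy group or an amine at this place would be needed to tell how far the trend extends.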